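This account rests on a few compounds, and the source may have more. Where it says the series, first, only, none or still open, it means among the compounds named here.

Compound 1 `CC1=CC[C@H](C(C)(C)N=C=S)CC1` sets the starting point: in a functional assay on MCF7 cells (Homo sapiens) for inhibition, read by sulforhodamine B assay, with a stated time of 48 h (on this read-out lower numbers stand for stronger inhibition of growth and higher numbers for weaker inhibition of growth), compound 1 gives 57600 nM. Compound 2 `COc1ccc(/C=N/NC(=S)NC(C)(C)[C@H]2CC=C(C)CC2)cc1` in this assay gives 31200 nM; set against compound 1, the gap between the two numbers lies within the usual scatter, so nothing separates them. Compound 3 `CC1=CC[C@H](C(C)(C)NC(=S)N/N=C/c2ccccc2O)CC1` has not yet been measured and differs from compound 2 only by 2-hydroxyphenyl in place of 4-methoxyphenyl on a carbon with a double bond to nitrogen. For the measured compounds named here, no measured step of this kind exists, so for compound 3 the expected shift is a 1.0-fold lower number from compound 2 to compound 3 (0.02 log units; within the scatter), nothing beyond the scatter in either direction. Compound 3 is therefore expected near 30000 nM, between 10000 nM and 90000 nM.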

Compound 3, concentration for 50% growth inhibition: 2200 nM
For compound 3 the middle estimate is 14-fold (1.13 log units) above the measured one, and the stated range ends above it.
By their numbers in this assay, from the lowest: compound 3; then compounds 2 and 1 (each within the scatter of the next).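

In this assay, for the compounds shown here, the group on a carbon with a double bond to nitrogen turns out to matter: 2-hydroxyphenyl in place of 4-methoxyphenyl gives a 14-fold lower number from compound 2 to compound 3 (1.15 log units; beyond the scatter) and so reveals a step that the earlier compounds did not show. The change swaps methoxy for hydroxy and also alters the ring number in the group's name, so the two cannot be told apart here. Nothing measured here explains the step. Going by these compounds, whether 4-hydroxyphenyl or 2-methoxyphenyl on the same carbon would keep the lower number remains open.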